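From 3-hydroxypropoxy to 2-bromoethoxy on the shared core

A few compounds are considered here, and "the series" means these few. Any claim that something is new, unique, unknown or untested is made for them only; others in the source may bear on it.

Of the compounds shown here, three built on one core have been tested in a functional assay on U-937 cells (Homo sapiens) for cytotoxicity, read by MTT assay, with a stated time of 24 h; on this read-out lower numbers stand for stronger inhibition and higher numbers for weaker inhibition. Compound 2 `OCCCOc1c(Br)cc(Br)cc1Oc1ccc(Br)cc1Br` gives 32.3 ug/mL, compound 3 `CC(C)(C)OC(=O)N1CCN(CCCCCOc2c(Br)cc(Br)cc2Oc2ccc(Br)cc2Br)CC1` gives 35.5 ug/mL and compound 1 `Brc1ccc(Oc2cc(Br)cc(Br)c2OCCCCCN2CCN(c3ccccc3)CC2)c(Br)c1` gives 42.5 ug/mL. Compound 2 thus stands within the scatter of both others, and the three numbers show no order.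

Compound 4 `BrCCOc1c(Br)cc(Br)cc1Oc1ccc(Br)cc1Br` differs from compound 2 in one place: bromo in place of hydroxymethyl on a saturated chain carbon, two bonds along the chain from an oxygen on an aromatic ring. Put another way, 3-hydroxypropoxy gives way to 2-bromoethoxy.

Among the compounds with values here, only one measured step links two compounds of this small set, namely a 1.2-fold lower number from compound 1 to compound 3 (0.08 log units; within the scatter). It puts tert-butoxycarbonyl in place of phenyl on an amine nitrogen in a ring, which is not the change made in compound 4, and it stays within the scatter. Within the data shown here, no measured pair shows bromo replacing hydroxymethyl, so direct evidence is lacking. Among the measured compounds shown here, the only indirect guide is that compound 2 at 32.3 ug/mL and compound 3 at 35.5 ug/mL lie within the scatter of each other despite their different chains. No shift beyond the scatter is therefore expected in this assay, and the expected step is a 1.0-fold lower number from compound 2 to compound 4 (0.00 log units; within the scatter). Compound 4 is estimated at 32 ug/mL, with an expected range from 17 ug/mL to 60 ug/mL.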

Compound 4, half-maximal inhibitory concentration: 32.5 ug/mL
Compound 4: the middle estimate sits 1.0-fold (0.01 log units) below what was measured; measured number inside the range.
By their numbers in this assay, from the lowest: compounds 2, 4, 3 and 1 (each within the scatter of the next).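

In this assay, within the data shown here, the step at this position, a 1.0-fold higher number from compound 2 to compound 4 (0.00 log units; within the scatter), gives the first direct reading of bromo in place of hydroxymethyl on a saturated chain carbon, two bonds along the chain from an oxygen on an aromatic ring. The earlier compounds shown here offered no such pair, and this one shows that the change, which also turns 3-hydroxypropoxy into 2-bromoethoxy, does not separate the two compounds beyond the scatter. For this pair, then, the hydrogen-bond donor and acceptor counted on hydroxymethyl, absent from bromo, are not needed to keep the number where compound 2 has it, and no available evidence bears on why the two compounds match.

The compounds shown leave open whether an amine or a carboxylic acid on the same chain carbon would stay within the scatter of compound 2 and compound 4 or move clearly away from them. They also leave open whether bromo and hydroxymethyl would still match on a longer chain, since this single pair speaks only for the chains it carries on the shared core.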